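One Stereocentre Drawn the Other Way in Compound 3

The source may hold more compounds than are shown below. What is called first, only, known or untested is meant among the compounds shown, and "the series" means these compounds.

Compound 1 `COc1ccc(C(CC(=O)N[C@@H](CC(C)C)B(O)O)NC(=O)c2ccccc2)cc1`: 5590 nM
Compound 2 `COc1ccc([C@H](CC(=O)N[C@@H](CC(C)C)B(O)O)NC(=O)c2ccccc2)cc1`: 5130 nM

In a functional assay on HepG2 cells (Homo sapiens) for cytotoxicity, read by MTT assay, with a stated time of 72 h (on this read-out lower numbers stand for stronger inhibition and higher numbers for weaker inhibition), compound 2 gives 5130 nM and compound 1 gives 5590 nM. These two values lie within the scatter of each other, so neither compound ranks ahead of the other. Compound 3 `COc1ccc([C@@H](CC(=O)N[C@@H](CC(C)C)B(O)O)NC(=O)c2ccccc2)cc1` departs from compound 2 by the two compounds have the same atoms and bonds and differ only in configuration as drawn: 1 of 2 stereo elements differ; a stereocentre at a saturated chain carbon is drawn S in compound 2 and R in compound 3, so a stereocentre at a saturated chain carbon is drawn S in compound 2 and R in compound 3. Among the compounds with values here, one measured step bears on this centre: a 1.1-fold lower number from compound 1 to compound 2 (0.04 log units; within the scatter), and it rests on (the fact that one of compounds 1 and 2 is drawn with a defined configuration and the other without, at the place where they differ). Compound 1 has no configuration drawn there, so it gives only indirect guidance on the R form. On that step, no change beyond the scatter is expected in this assay, and the expected step is a 1.1-fold higher number from compound 2 to compound 3 (0.05 log units; within the scatter). Compound 3 is estimated at 5800 nM, with an expected range from 2900 nM to 11000 nM.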

Compound 3, half-maximal inhibitory concentration: 1880 nM
Beside the measured number, compound 3's estimate is 3.1-fold (0.49 log units) above it; the measured number lies below the stated range.
By their numbers in this assay, from the lowest: compound 3; then compounds 2 and 1 (each within the scatter of the next).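

The configuration at this saturated chain carbon matters in this assay: the R form separates from the S form, with a 2.7-fold lower number from compound 2 to compound 3 (0.44 log units; beyond the scatter). The R form also separates from the compound drawn without a configuration there, with a 3.0-fold lower number from compound 1 to compound 3 (0.47 log units; beyond the scatter), whereas compound 1 and compound 2 lie within the scatter of each other. Compound 3 is therefore the only one of the three whose number stands apart, and the sole structural difference accompanying its step from compound 2 is this: the fact that compounds 2 and 3 differ only in the configuration as drawn

From the compounds shown here alone, the second stereocentre is drawn the same way in all three compounds, so its own contribution remains unknown. Going by these compounds, it also remains open whether the gap between the R and S forms would persist with a carboxylic acid in place of the boronic acid.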